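From 2-fluorophenyl to 2,3-dihydroxyphenyl on a shared core

This account rests on a few compounds, and the source may have more. Where it says the series, first, only, none or still open, it means among the compounds named here.

In a functional assay on microsomes for inhibition, with a stated time of 1 h (on this read-out lower numbers stand for stronger inhibition and higher numbers for weaker inhibition), compound 1 (`CCOC(=O)c1cnn(-c2nc(-c3ccccc3F)c(C#N)c(=O)n2C)c1N`) gives 94 ug/mL while compound 2 (`CSc1nc(-c2cccs2)c(C#N)c(=O)n1C`) gives 83 ug/mL and compound 3 (`Cn1c(NN)nc(-c2cccs2)c(C#N)c1=O`) gives 68 ug/mL so that all three numbers lie within the scatter of one another. Compound 4 (`CCOC(=O)c1cnn(-c2nc(-c3cccc(O)c3O)c(C#N)c(=O)n2C)c1N`) keeps the core of compound 1 but carries 2,3-dihydroxyphenyl in place of 2-fluorophenyl on an aromatic carbon ortho to a cyano group (2,3-dihydroxyphenyl in place of 2-fluorophenyl on an aromatic carbon). Among the compounds with values here, no measured step makes this replacement. Within the data shown here, the only measured step is a 1.2-fold lower number from compound 2 to compound 3 (0.09 log units; within the scatter) and it is aminoamino in place of methylsulfanyl, within the scatter and with no 2-fluorophenyl involved, so it bears on the change only loosely. With so little to go on, the expectation rests mainly on the closeness of the three values, and no step beyond the scatter is expected. The estimated change is a 1.2-fold lower number from compound 1 to compound 4 (0.07 log units; within the scatter) in either direction as a real possibility. In this assay the estimate for compound 4 is 80 ug/mL with an expected range from 40 ug/mL to 160 ug/mL as its bounds.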

Compound 4, half-maximal inhibitory concentration: 49 ug/mL
Compound 4: the middle estimate sits 1.6-fold (0.21 log units) above what was measured, and the stated range covers the measured number.
By their numbers in this assay, from the lowest: compounds 4, 3, 2 and 1 (each within the scatter of the next).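

In this assay, within the data shown here, replacing 2-fluorophenyl with 2,3-dihydroxyphenyl gives a 1.9-fold lower number from compound 1 to compound 4 (0.28 log units; within the scatter), and this is the only measured step at this position. The aromatic carbon ortho to a cyano group thus carries either group on the shared core without a change beyond the scatter, although 2,3-dihydroxyphenyl brings hydrogen-bond donors and acceptors that 2-fluorophenyl lacks. No measurement available here accounts for the size of this step.

The compounds shown leave open whether either hydroxyl alone would give the same result, since no phenyl group with a single hydroxyl appears among them. They also leave open how this position would respond to a methoxy group, an amine or a carboxylic acid on the phenyl ring, any of which might or might not move the number beyond the scatter.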